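Replacing a dimethylamino chain with methoxycarbonyl

This account rests on a few compounds, and the source may have more. Where it says the series, first, only, none or still open, it means among the compounds named here.

In a functional assay on HCT-116 cells (Homo sapiens) for cytotoxicity, read by scintillation counting and thymidine incorporation, with a stated time of 72 h (a higher number here means a weaker inhibitor, a lower number a stronger inhibitor), compound 1 (`CCC=C(c1cc(OC)cc(OC)c1)c1ccc(OC)c(OC)c1`) gives > 10000 nM, which is a limit and not a number. Compound 2 (`COc1cc(OC)cc(C(=CCCN(C)C)c2ccc(OC)c(OC)c2)c1`) gives > 10000 nM, also a limit. The two compounds therefore share (the limit of > 10000 nM in this assay, at which 2 of the 2 values shown sit). Among the measured compounds shown here, the only measured step is a step that the two limits leave unreadable from compound 1 to compound 2, so it offers no size to carry forward. Compound 3 (`COC(=O)C=C(c1cc(OC)cc(OC)c1)c1ccc(OC)c(OC)c1`) differs from compound 2 by methoxycarbonyl in place of 2-(dimethylamino)ethyl on a double-bonded chain carbon bound to a double-bonded chain carbon. No clear change in this assay is expected, and the estimate is a step that the limit leaves unreadable from compound 2 to compound 3, with no direction expected beyond the scatter. The estimated value for compound 3 is 15000 nM, within a range of 4000 nM to 50000 nM.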

Compound 3, half-maximal inhibitory concentration: > 10000 nM
Compound 3 gave a limit, no number; the forecaster's own chance of this, stated with the estimate: 85%; the middle value does not contradict the limit.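

No step can be read among compound 1, compound 2 and compound 3, because all three share one limit and give no number: the limit of > 10000 nM in this assay, at which 3 of the 3 values shown sit.

Going by these compounds, how the ethyl, 2-(dimethylamino)ethyl and methoxycarbonyl groups truly compare in this assay stays open.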